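Piperidin-1-yl in place of pyrrolidin-1-yl, bromine-bearing pair

The compounds below may be only part of what the source reports. "The series", "measured", "known", "first", "only" and "open" are said of these compounds alone.

For the measured compounds named here, in a functional assay on MCF7 cells (Homo sapiens) for antiproliferative activity, read by MTT assay, with a stated time of 48 h (a higher number here means a weaker inhibitor, a lower number a stronger inhibitor), compound 2 (`O=C(CN1CCCC1)Nc1ccc2ncnc(Nc3cccc(Br)c3)c2c1`) gives 12000 nM as the only number so far. The reading for compound 1 (`O=C(CN1CCCCC1)Nc1ccc2ncnc(Nc3cccc(C(F)(F)F)c3)c2c1`) is > 100000 nM and is a limit of the assay, not a number.

Compound 3 (`O=C(CN1CCCCC1)Nc1ccc2ncnc(Nc3cccc(Br)c3)c2c1`) is still unmeasured and differs from compound 2 in one place (piperidin-1-yl in place of pyrrolidin-1-yl on a saturated chain carbon bound to a carbonyl carbon): piperidin-1-yl in place of pyrrolidin-1-yl on a saturated chain carbon bound to a carbonyl carbon. Compound 1 also carries piperidin-1-yl, though with trifluoromethyl where compound 3 has bromine. For compound 1, the limit of > 100000 nM tilts the expectation towards weaker inhibition. The expected step is a 1.7-fold higher number from compound 2 to compound 3 (0.22 log units; within the scatter) in that direction, small and close to the usual scatter. In this assay the estimate for compound 3 is 20000 nM with an expected range from 6000 nM to 70000 nM for the measurement.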

Compound 3, half-maximal inhibitory concentration: 3000 nM
Beside the measured number, compound 3's estimate is 6.7-fold (0.82 log units) above it, and the stated range ends above it.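

At this saturated chain carbon bound to a carbonyl carbon, the outcome in this assay depends on the ring: piperidin-1-yl in place of pyrrolidin-1-yl gives a 4.0-fold lower number from compound 2 to compound 3 (0.60 log units; beyond the scatter), a modest gain with bromine held constant. With piperidin-1-yl held constant, bromo in place of trifluoromethyl on an aromatic carbon gives an at least 33-fold lower number from compound 1 to compound 3 (1.52 log units; beyond the scatter), a large step that shows piperidin-1-yl alone does not secure activity. That step has an open end, since the reading for compound 1 is a limit of the assay and not a number: the limit of > 100000 nM in this assay, at which 1 of the 3 values shown sits.

On these data alone, whether the gain from piperidin-1-yl carries over to a trifluoromethyl-bearing compound remains open. Also open, as far as these compounds go, is whether morpholine or dimethylamino at this carbon, or chloro in place of bromo on the aromatic carbon, would keep or extend the gain.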